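The source may hold more compounds than are shown below. What is called first, only, known or untested is meant among the compounds shown, and "the series" means these compounds.

Measured so far in an ADME assay on MT4 cells (Homo sapiens) for cytotoxicity, read by MTT assay, with a stated time of 96 h; a lower number here means that less compound is tolerated, a higher number that more compound is tolerated:
compound 1 `NS(=O)(=O)c1ccc(N2N=C(c3ccc(OCc4ccccc4)cc3)CC2c2ccc(Cl)cc2)cc1`: 70000 nM
compound 2 `Cc1cccc(C2CC(c3ccc(OCc4ccccc4)cc3)=NN2c2ccc(S(N)(=O)=O)cc2)c1`: 44000 nM

With only these two numbers, compound 2 stands level with compound 1, and the two cannot be ranked. The next compound is compound 3 `NS(=O)(=O)c1ccc(N2N=C(c3ccc(OCc4ccccc4)cc3)CC2c2cccc(F)c2)cc1`, which keeps the shared core and alters one small group: fluoro in place of methyl on an aromatic carbon. In words, this is fluoro in place of methyl on an aromatic carbon, turning 3-methylphenyl into 3-fluorophenyl. Among the compounds with values here, one measured step bears on it, a 1.6-fold lower number from compound 1 to compound 2 (0.20 log units; within the scatter), which put 3-methylphenyl in place of 4-chlorophenyl on a saturated ring carbon. That swap of a substituted phenyl stayed small, so no change beyond the scatter is expected in this assay here. The expected step is a 1.2-fold higher number from compound 2 to compound 3 (0.07 log units; within the scatter). For compound 3 the estimated value is 52000 nM, with an expected range from 25000 nM to 100000 nM.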

Compound 3, half-maximal cytotoxic concentration: 65000 nM
For compound 3 the middle estimate is 1.3-fold (0.10 log units) below the measured one, within the range that was stated.
By their numbers in this assay, from the lowest: compounds 2, 3 and 1 (each within the scatter of the next).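

In this assay, fluoro in place of methyl on an aromatic carbon, meta to a large group, gives a step that stays within the scatter (a 1.5-fold higher number from compound 2 to compound 3 (0.17 log units; within the scatter)). Within the data shown here, the 3-fluorophenyl form also cannot be told apart from the 4-chlorophenyl form (a 1.1-fold lower number from compound 1 to compound 3 (0.03 log units; within the scatter)), so this is the first sign that all three small variations on this phenyl ring stand level in how much compound the cells tolerate. No measurement at hand offers a reason for this sameness.

From the compounds shown here alone, all three groups tried here are small, so it remains open whether a different kind of group on this phenyl ring, such as an amine, a carboxylic acid or a longer chain, would move the number beyond the scatter. The same question holds for the benzyloxy-bearing side of the shared core, which stays unchanged across these compounds.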